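The source may hold more compounds than are shown below. What is called first, only, known or untested is meant among the compounds shown, and "the series" means these compounds.

In an ADME assay on microsomes from liver (Homo sapiens) for metabolic stability (a lower number here means slower removal, a higher number faster removal of the compound), compound 1 `N#Cc1ccc(Oc2cc(-c3cnnc4c3ncn4C3CC3)ccc2F)nc1` stands lowest of the two numbers at 17 mL.min-1.g-1 while compound 2 `CC(C)n1cnc2c(-c3ccc(F)c(Oc4ccc(C#N)cn4)c3)cnnc21` gives 38 mL.min-1.g-1 so far. Compound 3 `Cc1cc(-c2cc(-c3cnnc4c3ncn4C3CC3)ccc2F)ccn1` carries 2-methylpyridin-4-yl in place of (5-cyanopyridin-2-yl)oxy on an aromatic carbon. Among the measured compounds shown here, no measured step covers this swap. For the measured compounds named here, the only step, isopropyl in place of cyclopropyl on an aromatic nitrogen, is a 2.2-fold higher number from compound 1 to compound 2 (0.35 log units; beyond the scatter) and is modest, so it offers only a rough guide to size. No clear step beyond the scatter is expected, and the estimated change is a 1.5-fold higher number from compound 1 to compound 3 (0.17 log units; within the scatter) with wide uncertainty. Compound 3 is estimated at 25 mL.min-1.g-1 with 10 mL.min-1.g-1 to 60 mL.min-1.g-1 as the expected range.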

Compound 3, intrinsic clearance in microsomes in the Homo sapiens assay: 42 mL.min-1.g-1
The estimate for compound 3 lay 1.7-fold (0.23 log units) below the measured number, and the stated range covers the measured number.
By their numbers in the Homo sapiens assay, from the lowest: compound 1; then compounds 2 and 3 (each within the scatter of the next).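

The earlier pair changed only the group on the aromatic nitrogen, whereas this result shows that the aromatic carbon ortho to a fluoro group also affects clearance in the Homo sapiens assay, with a 2.5-fold higher number from compound 1 to compound 3 (0.39 log units; beyond the scatter) when 2-methylpyridin-4-yl replaces (5-cyanopyridin-2-yl)oxy. In a physicochemical assay for lipophilicity (a higher number here means a more lipophilic compound, a lower number a more polar compound), compound 1 gives 2.3 and compound 3 gives 2.9, so the same swap gives a more lipophilic compound, and faster removal travels with higher lipophilicity in this one pair: the measured distribution coefficient of compound 1, 2.3, and of compound 3, 2.9, a number 0.60 log units higher (beyond the scatter).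

On these data alone, the oxygen, the nitrile and the methyl all change at once, so which of them matters stays open. Also open, as far as these compounds go, is how an amine or a carboxylic acid at this position would behave.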